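The compounds below may be only part of what the source reports. "The series", "measured", "known", "first", "only" and "open" are said of these compounds alone.

Measured compounds:
- Compound 1, `O=C(O)Cc1sc(C(c2ccc(F)cc2)c2ccc(F)cc2)nc1-c1ccc(Cl)cc1`: in an in vitro assay on HEK385-7 cells for displacement of a labelled ligand from prostaglandin D2 receptor 2 (Homo sapiens) (a lower number here means a stronger inhibitor, a higher number a weaker inhibitor), compound 1 gives 9.7 nM.
- Compound 2, `O=C(O)Cc1sc(C(c2ccc(F)cc2)c2ccc(F)cc2)nc1-c1cccc(F)c1`: in this assay compound 2 gives 1.4 nM.
- Compound 3, `NS(=O)(=O)c1ccc(-c2nc(C(c3ccc(F)cc3)c3ccc(F)cc3)sc2CC(=O)O)cc1`: in this assay compound 3 gives 1500 nM.

All three share the same core and differ only in the aromatic group attached next to the ring nitrogen. Compound 3 stands highest of the three numbers, meaning it is the weakest inhibitor here: the step of a 150-fold higher number from compound 1 to compound 3 (2.19 log units; beyond the scatter) and the step of a 1100-fold higher number from compound 2 to compound 3 (3.03 log units; beyond the scatter) are both large and well beyond the scatter. The smaller change between the other two, a 6.9-fold lower number from compound 1 to compound 2 (0.84 log units; beyond the scatter), is modest by comparison.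

Compound 4, `O=C(O)Cc1sc(C(c2ccc(F)cc2)c2ccc(F)cc2)nc1-c1ccoc1`, has not yet been measured. It differs from compound 3 in one place: furan-3-yl in place of 4-sulfamoylphenyl on an aromatic carbon. The two steps that bear on this change are the ones that introduced the sulfamoylphenyl group, from compound 1 and from compound 2, and both raised the number greatly. Among the compounds with values here, removing that group and putting a small five-membered ring in its place is therefore expected to move the number back down by a large amount, in the direction of compounds 1 and 2, though the furan ring has no direct precedent among the measured compounds, so the expectation carries a wide range. The expected step is a 75-fold lower number from compound 3 to compound 4 (1.88 log units; beyond the scatter). Compound 4 is estimated at 20 nM in this assay, within a range of 4 nM to 120 nM.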

Compound 4, half-maximal inhibitory concentration: 14 nM
For compound 4 the middle estimate is 1.4-fold (0.15 log units) above the measured one; the range from low to high includes it.
By their numbers in this assay, from the lowest: compound 2; then compounds 1 and 4 (each within the scatter of the next); then compound 3.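

At this position, on the aromatic carbon next to the ring nitrogen, a six-membered aromatic ring of carbon only is not required for a low number in this assay: the five-membered furan-3-yl ring matches the 4-chlorophenyl group, with a 1.4-fold higher number from compound 1 to compound 4 (0.16 log units; within the scatter). The a 110-fold lower number from compound 3 to compound 4 (2.03 log units; beyond the scatter) adds a third group with a number far lower than that of 4-sulfamoylphenyl, so among the four compounds that group stands alone at the high end, while the other three groups all give much lower numbers. The position still separates the groups that do well, however: a 10-fold higher number from compound 2 to compound 4 (1.00 log units; beyond the scatter), so exchanging 3-fluorophenyl for furan-3-yl costs more than the usual scatter, even though furan-3-yl and 4-chlorophenyl cannot be told apart.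

Nothing given here explains why these groups differ in this way. Also open, as far as these compounds go, is how the numbers would move with thiophen-3-yl or furan-2-yl in place of furan-3-yl, with an unsubstituted phenyl ring as a reference for both fluoro and chloro, or with 3-sulfamoylphenyl, which would show whether the high number follows the sulfamoyl group wherever it sits on the phenyl ring.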